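The source may report more compounds than this note shows. Statements on the series, on what has been measured and on what is new or still open speak of the compounds shown alone.

Working notes on the series. The read-out followed is a physicochemical assay for solubility, at pH 7.4; on this read-out lower numbers stand for lower solubility and higher numbers for higher solubility. Compound 1 `O=C(NCc1ccc(-c2noc(CCC3CC3)n2)cc1)[C@H]1NCC[C@@H]1O` returns only a limit in this assay, namely > 50 ug/mL, so its true value is not pinned down. Compound 2 `CCCCCCCc1noc(-c2ccc(CNC(=O)[C@H]3NCC[C@@H]3O)cc2)n1` gives 3 ug/mL in this assay. Among the measured compounds shown here, of the two values shown, one sits at the limit of > 50 ug/mL in this assay, at which 1 of the 2 values shown sits, and the other is a measured number; no step between the two is established here, and the pair is read only as what its values show. Compound 3 `CC1(c2nc(-c3ccc(CNC(=O)[C@H]4NCC[C@@H]4O)cc3)no2)CCCCC1` is the next point to be measured: 1-methylcyclohexyl in place of 2-cyclopropylethyl on an aromatic carbon. In this assay a downward step beyond the usual scatter is expected, estimated as an at least 5.0-fold lower number from compound 1 to compound 3 (0.69 log units; beyond the scatter). The estimate for compound 3 in this assay is 10 ug/mL, with an expected range from 3 ug/mL to 40 ug/mL.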

Compound 3, solubility: > 50 ug/mL
Compound 3: only a limit was reported (the forecaster's own chance of this, stated with the estimate: 15%); middle value at least 5.0-fold (0.69 log units) away from the limit.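

Compound 1 and compound 3 both return only a limit in this assay, so no step between them can be read: the limit of > 50 ug/mL in this assay, at which 2 of the 3 values shown sit.

The compounds shown leave open the true values of compound 1 and compound 3, and so whether 1-methylcyclohexyl in place of 2-cyclopropylethyl shifts this read-out at all.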